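The compounds below may be only part of what the source reports. "The series", "measured", "known", "first", "only" and "open" are said of these compounds alone.

So far, two compounds have been measured: compound 1 (`O=S(=O)(/C=C/c1ccc(Cl)c(Cl)c1)Cc1ccc(Nc2ncnc3ccccc23)cc1`) and compound 2 (`O=S(=O)(/C=C/c1ccc(Cl)cc1)Cc1ccc(Nc2ncnc3ccccc23)cc1`). Within the data shown here, in a functional assay on UACC-62 cells (Homo sapiens) (a higher number here means a weaker inhibitor of growth, a lower number a stronger inhibitor of growth), compound 1 gives 21000 nM and compound 2 gives 13000 nM, so compound 2 cannot be told apart from its only neighbour on these numbers.

Compound 3 (`O=S(=O)(/C=C/c1ccc(Cl)cc1Cl)Cc1ccc(Nc2ncnc3ccccc23)cc1`) differs from compound 2 by chloro in place of hydrogen on an aromatic carbon, ortho to a large group and meta to a chloro group. This turns 4-chlorophenyl into 2,4-dichlorophenyl.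

Among the measured compounds shown here, one measured step bears on this change. It swaps the same two atoms, though on a different aromatic carbon, and it stays within the scatter: a 1.6-fold lower number from compound 1 to compound 2 (0.21 log units; within the scatter). No step beyond the scatter is therefore expected in this assay, and no firm direction can be given. The expected step is a 1.2-fold higher number from compound 2 to compound 3 (0.09 log units; within the scatter). For compound 3 the estimated value is 16000 nM, with an expected range of 7000 nM to 35000 nM.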

Compound 3, concentration for 50% growth inhibition: 2000 nM
Estimate against measurement, compound 3: 8.0-fold (0.90 log units) above; the measured number lies below the stated range.
By their numbers in this assay, from the lowest: compound 3; then compounds 2 and 1 (each within the scatter of the next).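

In this assay, adding a chloro group to the 4-chlorophenyl ring, ortho to a large group and meta to a chloro group, gives a clear move towards stronger growth inhibition (a 6.5-fold lower number from compound 2 to compound 3 (0.81 log units; beyond the scatter)), whereas the earlier change on a different aromatic carbon stayed within the scatter (a 1.6-fold lower number from compound 1 to compound 2 (0.21 log units; within the scatter)). The placement of the second chlorine also matters, since 2,4-dichlorophenyl in place of 3,4-dichlorophenyl produces a large step in the same direction (an 11-fold lower number from compound 1 to compound 3 (1.02 log units; beyond the scatter)). No measurement shown here accounts for this difference between the two positions.

On these data alone, it remains open whether fluoro, methyl or methoxy at this same place would give a step of similar size. As far as these compounds go, it is also open whether the step depends on the chloro group already present on the ring.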